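The source may hold more compounds than are shown below. What is called first, only, known or untested is meant among the compounds shown, and "the series" means these compounds.

Compound 1 `COc1ccc(/C=C/C2CC=CC(=O)O2)cc1OC` gives 11.6 uM in a functional assay on NCI/ADR cells (Homo sapiens) for inhibition, read by sulforhodamine B assay, with a stated time of 48 h; a higher number here means a weaker inhibitor of growth, a lower number a stronger inhibitor of growth. Compound 2 `COc1cc(OC)c(OC)cc1/C=C/C1CC=CC(=O)O1` gives 9.4 uM in this assay.

In this assay, for the measured compounds named here, compound 2 stands among only two numbers, and the single measured step, a 1.2-fold lower number from compound 1 to compound 2 (0.09 log units; within the scatter), is within the scatter. Compound 3 `COc1cc(OC)c(OC)cc1/C=C/C1CC=CC(=O)N1` has not been measured; it differs from compound 2 by a group of 7 heavy atoms (5 carbon, 1 nitrogen, 1 oxygen; one six-membered non-aromatic ring with 1 hetero atom) in place of a group of 7 heavy atoms (5 carbon, 2 oxygen; one six-membered non-aromatic ring with 1 hetero atom), on a double-bonded chain carbon bound to a double-bonded chain carbon. That one step concerns a methoxy on an aromatic carbon and bears nothing on this exchange, so no direction can be drawn from it. Compound 3 is therefore expected to move only modestly, a 1.6-fold higher number from compound 2 to compound 3 (0.20 log units; within the scatter). The estimate for compound 3 in this assay is 15 uM, between 5 uM and 45 uM.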

Compound 3, concentration for growth inhibition (reported as GI): > 864 uM
Compound 3 was reported as a limit; the forecaster's own chance of this, stated with the estimate: 10%; middle value at least 57-fold (1.76 log units) from the limit.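

The group with 1 nitrogen and 1 oxygen, in place of the group with 2 oxygen, on a double-bonded chain carbon bound to a double-bonded chain carbon, gives an at least 91-fold higher number from compound 2 to compound 3 (1.96 log units; beyond the scatter) in this assay. Unlike the methoxy step, this change lies beyond the scatter, so growth inhibition here proved sensitive to this exchange. Compound 3 is reported only as a limit, not a number: the limit of > 864 uM in this assay, at which 1 of the 3 values shown sits.

The compounds shown leave open how far compound 3 lies past that limit. They also leave open whether a methyl group on the ring nitrogen, or a sulfur in place of the ring oxygen, would keep the inhibition.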